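The source may report more compounds than this note shows. Statements on the series, on what has been measured and on what is new or still open speak of the compounds shown alone.

Going by the values given here, in a functional assay on HCT-116 cells (Homo sapiens) for antiproliferative activity, read by sulforhodamine B assay, with a stated time of 72 h (on this read-out lower numbers stand for stronger inhibition and higher numbers for weaker inhibition), three compounds have numbers so far. Compound 1 (`Cn1ncc(Cl)c1-c1cc(C(=O)N[C@@H]2CN[C@H](CCCO)C[C@H]2c2ccc(Cl)c(Cl)c2)oc1Cl`) gives 510 nM and compound 2 (`CC(=O)NCC[C@@H]1C[C@@H](c2ccc(F)c(F)c2)[C@H](NC(=O)c2cc(-c3c(Cl)cnn3C)c(Cl)o2)CN1`) gives 920 nM, two values that lie within the scatter of each other. Compound 3 (`O=C(N[C@@H]1CNCC[C@H]1c1ccc(Cl)cc1)c1ccc(-c2ncnc3c2CCC3O)s1`) gives 23000 nM, a number well beyond the scatter from that of compound 1. Compound 1 therefore sits in the low group of these three numbers, together with compound 2.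

The next compound to be measured is compound 4 (`CCC[C@@H]1C[C@@H](c2ccc(Cl)c(Cl)c2)[C@H](NC(=O)c2cc(-c3c(Cl)cnn3C)c(Cl)o2)CN1`). It keeps the core of compound 1 and differs from it in one place: hydrogen in place of hydroxy on a saturated chain carbon, three bonds along the chain from a saturated ring carbon. In words, the 3-hydroxypropyl group becomes propyl, with hydrogen in place of hydroxy on a saturated chain carbon, three bonds along the chain from a saturated ring carbon.

Among the compounds with values here, no measured pair isolates this change, so the data give no direct size for it, and no direction can be read from them. The expectation is therefore a modest one, with no step beyond the scatter in this assay. The estimated change, a 1.3-fold lower number from compound 1 to compound 4 (0.11 log units; within the scatter), is expected to stay within the scatter. For compound 4 the estimated value is 400 nM, with an expected range from 150 nM to 1100 nM.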

Compound 4, half-maximal inhibitory concentration: 1020 nM
Compound 4: the middle estimate sits 2.6-fold (0.41 log units) below what was measured; low and high end bracket the measured number.
By their numbers in this assay, from the lowest: compounds 1, 2 and 4 (each within the scatter of the next); then compound 3.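

In this assay, going by these compounds alone, this is the first pair to isolate the change from 3-hydroxypropyl to propyl, and it gives a 2.0-fold higher number from compound 1 to compound 4 (0.30 log units; within the scatter) on the core of compound 1. The step therefore gives no sign that the hydroxy group on this saturated chain carbon, three bonds along the chain from a saturated ring carbon, matters to the number in this assay: with it or without it, the two compounds cannot be told apart here. Nothing among the data shown accounts for how close the two numbers lie.

The compounds shown leave open what happens when the end of this chain carries an amine or a carboxylic acid, and whether a longer chain or a shorter one such as ethyl or methyl would also leave the number within the scatter of that of compound 1. They also leave open whether the same change from hydroxy to hydrogen would give a step of similar size with other groups elsewhere on the shared core.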